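A few compounds are considered here, and "the series" means these few. Any claim that something is new, unique, unknown or untested is made for them only; others in the source may bear on it.

Values in a functional assay on HepG2 cells (Homo sapiens) for inhibition, read by sulforhodamine B assay, with a stated time of 72 h; on this read-out higher numbers stand for weaker inhibition and lower numbers for stronger inhibition:
- compound 1 `C[C@H](Nc1ncnc2[nH]cnc12)c1nn(-c2cccc(F)c2)c2cc(F)ccc12`: 32300 nM
- compound 2 `C[C@H](Nc1ncnc2[nH]cnc12)c1nn(-c2ccccn2)c2cc(F)ccc12`: 29900 nM
- compound 3 `C[C@H](Nc1ncnc2[nH]cnc12)c1nn(-c2cc(F)cc(F)c2)c2cc(F)ccc12`: 22100 nM

Compound 3 does not stand apart from the other two, as both of its steps stay within the scatter: a 1.5-fold lower number from compound 1 to compound 3 (0.16 log units; within the scatter) and a 1.4-fold lower number from compound 2 to compound 3 (0.13 log units; within the scatter).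

Compound 4 `C[C@H](Nc1ncnc2[nH]cnc12)c1nn(-c2ccncc2)c2cc(F)ccc12` has pyridin-4-yl in place of 3,5-difluorophenyl on an aromatic nitrogen.

Going by the values given here, no measured compound carries pyridin-4-yl, so the nearest evidence comes from the pyridin-2-yl of compound 2. Among the compounds with values here, two steps bear on the change: a 1.4-fold lower number from compound 2 to compound 3 (0.13 log units; within the scatter) and a 1.1-fold lower number from compound 1 to compound 2 (0.03 log units; within the scatter). Both exchange a pyridinyl for a fluorinated phenyl or the reverse, and neither moves the number beyond the scatter. The same is therefore expected here in this assay, with no clear direction.

The expected step is a 1.2-fold higher number from compound 3 to compound 4 (0.09 log units; within the scatter). For compound 4 the estimate is 27000 nM, with an expected range of 13000 nM to 55000 nM.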

Compound 4, half-maximal inhibitory concentration: 23100 nM
Beside the measured number, compound 4's estimate is 1.2-fold (0.07 log units) above it; the measured number falls inside the stated range.
By their numbers in this assay, from the lowest: compounds 3, 4, 2 and 1 (each within the scatter of the next).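

In this assay, going by these compounds alone, compound 4 shows that swapping one pyridine isomer for the other on the aromatic nitrogen leaves the number within the scatter (a 1.3-fold lower number from compound 2 to compound 4 (0.11 log units; within the scatter)), a comparison the earlier compounds could not offer. Exchanging a fluorinated phenyl for pyridin-4-yl, which brings in a hydrogen-bond acceptor, also stays within the scatter, both for the 3,5-difluorophenyl (a 1.0-fold higher number from compound 3 to compound 4 (0.02 log units; within the scatter)) and for the 3-fluorophenyl (a 1.4-fold lower number from compound 1 to compound 4 (0.15 log units; within the scatter)), so all four groups at this position read alike. No supporting data are available to account for this result.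

From the compounds shown here alone, all four groups are six-membered aromatic rings, so the effect of a saturated ring such as morpholine or of a small methyl at this position remains open. Also open, going by these compounds, is whether an amine or a carboxylic acid on the aromatic ring would move the number.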